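This account rests on a few compounds, and the source may have more. Where it says the series, first, only, none or still open, it means among the compounds named here.

Measured so far:
compound 1 `COc1cccc(/C(C)=C/CN(C)Cc2ccccc2)c1` gives 10 nM
compound 2 `C/C(=C\CN1CCCCC1)c1ccccc1` gives 459 nM

Both numbers come from an assay on cell membranes for displacement of a labelled ligand from Sigma non-opioid intracellular receptor 1 (Cavia porcellus), read by scintillation counting, with a stated time of 150 min; a lower number here means a stronger inhibitor, a higher number a weaker inhibitor. Compound 1 gives 10 nM, and compound 2 gives 459 nM. Compound 2 stands highest of the two numbers; its nearest neighbour is compound 1, and the gap between them is well beyond the usual scatter. The two compounds differ in more than one place, so no single step can be read between them; only the two values themselves are known.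

Compound 3 `C/C(=C\CN1CCCCC1)c1ccc(-c2ccccc2)cc1` has not yet been measured in this assay. It differs from compound 2 by phenyl in place of hydrogen on an aromatic carbon. Going by the values given here, no step between two measured compounds matches this change, so the expectation for compound 3 rests on the structural change and on compound 2 alone. The step of a 5.7-fold lower number from compound 2 to compound 3 (0.76 log units; beyond the scatter) is estimated to run toward a lower number, by more than the scatter, with a wide band of uncertainty. Compound 3 is expected near 80 nM, within 15 nM to 400 nM.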

Compound 3, inhibition constant: 0.86 nM
Compound 3: the middle estimate sits 93-fold (1.97 log units) above what was measured, outside the stated range (below it).
By their numbers in this assay, from the lowest: compound 3; then compound 1; then compound 2.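

In this assay, going by these compounds alone, phenyl in place of hydrogen on an aromatic carbon of the six-membered aromatic ring, para to a large group, gives a 530-fold lower number from compound 2 to compound 3 (2.73 log units; beyond the scatter) and is the first single-place change that can be read. The position therefore accepts a whole added aromatic ring of carbon only, and the large step comes from an entering group with no hydrogen-bond donors, no hydrogen-bond acceptors and no net charge. No measured property bears on the size of this step, so the data offer no account of it.

Phenyl is the only group shown at this position, so it remains open whether a chlorine atom, a saturated cyclohexyl ring, an amine or a carboxylic acid in the same place would give a step of similar size or direction. On these data alone, it is also open whether the same phenyl change would carry over to the core of compound 1, which differs from compound 2 in more than one place.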